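Thiophene Ketone Analogue in a Boron-Containing Pyrrole Series

The source may hold more compounds than are shown below. What is called first, only, known or untested is meant among the compounds shown, and "the series" means these compounds.

Compound 1 (`COc1ccc(CNC(=O)c2cccn2-c2ccc3c(c2)B(O)OC3)cc1`) and compound 2 (`O=C(c1ccn(-c2ccc3c(c2)B(O)OC3)c1)c1ccc(Cl)cc1Cl`) share the same core and were both examined in an ADME assay on L929 cells (Mus musculus) for cytotoxicity, read by resazurin assay, with a stated time of 72 h; a lower number here means a stronger inhibitor, a higher number a weaker inhibitor. In this assay compound 1 gives only a limit of the assay, > 10 ug/mL. In this assay compound 2 likewise gives only a limit, > 10 ug/mL. Compound 2 therefore stands at the limit of > 10 ug/mL in this assay, at which 2 of the 2 values shown sit, and no number sets it apart from compound 1. Compound 3 (`Cc1ccc(C(=O)c2ccn(-c3ccc4c(c3)B(O)OC4)c2)s1`) differs from compound 2 by 5-methylthiophen-2-yl in place of 2,4-dichlorophenyl on a carbonyl carbon. Among the compounds with values here, because both measured values are limits, no step between measured compounds can be sized. The step that the limit leaves unreadable from compound 2 to compound 3 is expected to be none beyond the scatter. Compound 3 is therefore expected to remain at the limit in this assay, estimated at 15 ug/mL with a range from 7 ug/mL to 40 ug/mL.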

Compound 3, half-maximal inhibitory concentration: > 10 ug/mL
Compound 3 was reported as a limit (the forecaster's own chance of this, stated with the estimate: 80%); the middle value is on the limit's open side.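

Within the data shown here, compound 3 gives only a limit in this assay, > 10 ug/mL, so no step from compound 2 to compound 3 can be read. The compounds shown leave open whether 5-methylthiophen-2-yl in place of 2,4-dichlorophenyl on a carbonyl carbon changes the read-out at all, with all three compounds at one value: the limit of > 10 ug/mL in this assay, at which 3 of the 3 values shown sit.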